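Swapping thiazole for pyrimidine on the shared core

The source may report more compounds than this note shows. Statements on the series, on what has been measured and on what is new or still open speak of the compounds shown alone.

The study covers three compounds built on a shared core, each carrying a 4-hydroxybutyl group on a five-membered ring. Compound 1 `O=c1n(Cc2nc(-c3nccs3)cn2CCCCO)c2cnccc2n1C1CC1` and compound 2 `COC(=O)N1CCC(n2c(=O)n(Cc3nc(C)c(C)n3CCCCO)c3cnccc32)CC1` have been measured in an ADME assay on microsomes from liver (Homo sapiens) for metabolic stability (a higher number here means faster removal of the compound, a lower number slower removal), and compound 3 `O=c1n(Cc2nc(-c3ncccn3)cn2CCCCO)c2cnccc2n1C1CC1` has not. In this assay compound 1 gives only a limit, < 8 mL.min-1.g-1. Compound 1 therefore sits at the limit of < 8 mL.min-1.g-1 in this assay, at which 1 of the 2 values shown sits, so where it stands is known only as a bound, not as a number. In this assay compound 2 gives 15 mL.min-1.g-1. Compound 3 differs from compound 1 by pyrimidin-2-yl in place of 1,3-thiazol-2-yl on an aromatic carbon. Among the measured compounds shown here, no measured pair of compounds differing in one place is available, so the size of this step is open. For compound 3 the step from compound 1 is expected to be small, a number no lower from compound 1 to compound 3 (the limit leaves the size open), within the usual scatter, and the estimated value for compound 3 in this assay is 8 mL.min-1.g-1, between 4 mL.min-1.g-1 and 16 mL.min-1.g-1.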

Compound 3, intrinsic clearance in microsomes: < 8 mL.min-1.g-1
Compound 3: no number, only a limit (the forecaster's own chance of this, stated with the estimate: 50%); the middle value lies on the limit itself.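

Among the compounds shown here, compound 1 and compound 3 both give only a limit in this assay, so no step between them can be read: the limit of < 8 mL.min-1.g-1 in this assay, at which 2 of the 3 values shown sit. The compounds shown leave open whether pyrimidin-2-yl in place of 1,3-thiazol-2-yl changes removal in this assay at all.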